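The source may hold more compounds than are shown below. What is called first, only, known or untested is meant among the compounds shown, and "the series" means these compounds.

Compound 3 `CC1CCN(C2CCN(S(=O)(=O)c3ccc(OC(F)(F)F)cc3)CC2)CC1` gives the lowest number of the three in a functional assay on DLD-1 cells (Homo sapiens) for antiproliferative activity, read by CellTiter-Glo, with a stated time of 72 h (on this read-out lower numbers stand for stronger inhibition and higher numbers for weaker inhibition), 16 nM. Compound 1 `CC1CCN(C2CCN(S(=O)(=O)c3ccc(-c4ccc(Cl)cc4)cc3)CC2)CC1` gives 105 nM and compound 2 `CC1CCN(C2CCN(S(=O)(=O)c3ccc(OCc4ccccc4)cc3)CC2)CC1` gives 385 nM. Compound 4 `COc1ccc(-c2ccc(S(=O)(=O)N3CCC(N4CCC(C)CC4)CC3)cc2)cc1` differs from compound 3 by 4-methoxyphenyl in place of trifluoromethoxy on an aromatic carbon. Among the compounds with values here, the steps that bear on this change are a 6.6-fold lower number from compound 1 to compound 3 (0.82 log units; beyond the scatter), a 24-fold lower number from compound 2 to compound 3 (1.38 log units; beyond the scatter) and a 3.7-fold higher number from compound 1 to compound 2 (0.56 log units; beyond the scatter): each departure from the trifluoromethoxy of compound 3 went with a higher number, and compound 4 returns to a group of the kind carried by compound 1, the 4-chlorophenyl. A modest upward step in this assay is therefore expected, a 7.5-fold higher number from compound 3 to compound 4 (0.88 log units; beyond the scatter). Compound 4 is estimated at 120 nM, within 40 nM to 400 nM.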

Compound 4, half-maximal inhibitory concentration: 263 nM
Compound 4: middle estimate off by 2.2-fold (0.34 log units), on the low side; the range from low to high includes it.
By their numbers in this assay, from the lowest: compound 3; then compound 1; then compounds 4 and 2 (each within the scatter of the next).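

At this aromatic carbon in this assay, 4-methoxyphenyl in place of trifluoromethoxy gives a large step (a 16-fold higher number from compound 3 to compound 4 (1.22 log units; beyond the scatter)), leaving compound 3 apart from all three compounds whose group carries a further ring. Among those, methoxy in place of chloro still moves the number (a 2.5-fold higher number from compound 1 to compound 4 (0.40 log units; beyond the scatter)), whereas 4-methoxyphenyl in place of benzyloxy stays within the scatter (a 1.5-fold lower number from compound 2 to compound 4 (0.17 log units; within the scatter)). No measurement at hand explains these steps.

Open, as far as these compounds go, is whether the low number of compound 3 belongs to trifluoromethoxy itself or to the lack of a further ring. A lone methoxy or a nitrile at this carbon would separate the two.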